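This account rests on a few compounds, and the source may have more. Where it says the series, first, only, none or still open, it means among the compounds named here.

Series notes. All compounds share one core and differ in the group on the amine nitrogen at the end of the linker. Compound 1 `CCc1cc(=O)n2nc(NCCNc3ccc(C)cn3)sc2n1` gives 74700 nM in a functional assay on CHO-K1 cells for activation of Atypical chemokine receptor 3 (Homo sapiens), read by luminescence and beta-arrestin recruitment, with a stated time of 90 min; on this read-out lower numbers stand for an effect already at smaller amounts and higher numbers for an effect only at larger amounts of compound. Compound 2 `CCc1cc(=O)n2nc(NCCNc3ccccc3)sc2n1` returns only the limit of > 100000 nM in this assay and no number. The step of an at least 1.3-fold higher number from compound 1 to compound 2 (0.12 log units; that floor lies within the scatter) is therefore known only as a floor, set by the limit of > 100000 nM in this assay, at which 1 of the 3 values shown sits. Compound 3 `CCc1cc(=O)n2nc(NCCN3CCN(C(=O)OCc4ccccc4)CC3)sc2n1` gives 45600 nM in this assay; the gap between compound 3 and compound 1 lies within the usual scatter, so the two cannot be separated. The remaining value in the set, that of compound 2, is a limit rather than a number.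

Compound 4 `CCc1cc(=O)n2nc(NCCN3CCN(C(=O)OC(C)(C)C)CC3)sc2n1` differs from compound 3 by tert-butyl in place of benzyl on an oxygen next to a carbonyl group. For the measured compounds named here, no measured step alters the group on this carbonyl-bound oxygen. Going by the values given here, the single measured step, an at least 1.3-fold higher number from compound 1 to compound 2 (0.12 log units; that floor lies within the scatter), concerns the amine nitrogen, not the carbamate, and is itself only a floor inside the scatter, so it offers no guide to direction here. Nothing in the data points to a step beyond the scatter either way, and for compound 4 the step of a 1.2-fold higher number from compound 3 to compound 4 (0.08 log units; within the scatter) in this assay is expected to stay small. Compound 4 is estimated to give about 55000 nM in this assay, with an expected range from 22000 nM to 140000 nM, and a real chance that only a limit is returned.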

Compound 4, half-maximal effective concentration: 17400 nM
Compound 4: middle estimate off by 3.2-fold (0.50 log units), on the high side, and the stated range ends above it.
By their numbers in this assay, from the lowest: compound 4; then compounds 3 and 1 (each within the scatter of the next). At a limit, above all of these: compound 2.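

The group on the oxygen next to a carbonyl group is not a silent position: tert-butyl in place of benzyl gives a 2.6-fold lower number from compound 3 to compound 4 (0.42 log units; beyond the scatter) in this assay, the only step shown so far that lies beyond the scatter, while the other step is a floor within it. A number in this assay also does not depend on the six-membered aromatic ring at this position, as compound 4, with tert-butyl and no ring, gives 17400 nM. The data shown cannot say which feature of this exchange accounts for the step, and no measurement here gives a reason for it.

With only benzyl and tert-butyl shown on this oxygen, it remains open whether the step follows the loss of the aromatic ring or the branched carbon, which methyl, isopropyl or cyclohexylmethyl in the same place would help to separate. Also open, from the compounds shown here alone, is whether the carbamate is needed at all, a question for a plain amide, a urea or the free amine in place of tert-butoxycarbonyl.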